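Swapping Trifluoromethyl for Hydroxy on the Aryl Urea

The source may hold more compounds than are shown below. What is called first, only, known or untested is meant among the compounds shown, and "the series" means these compounds.

Compound 2 `COc1cc(NC(C)CCCNC(=O)NNC(=O)Nc2ccc(C(F)(F)F)cc2)c2ncccc2c1` gives 18000 nM in a functional assay on L1210 cells (Mus musculus) for inhibition, read by MTT assay, with a stated time of 72 h; on this read-out lower numbers stand for stronger inhibition and higher numbers for weaker inhibition. It stands level with compound 3 `COc1cc(NC(C)CCCNC(=O)NNC(=O)Nc2cc(C(F)(F)F)cc(C(F)(F)F)c2)c2ncccc2c1`, which gives 18000 nM in this assay; together they show the lowest numbers of the three. For the measured compounds named here, compound 1 `COc1cc(NC(C)CCCNC(=O)NNC(=O)Nc2ccc(Cl)cc2)c2ncccc2c1` gives 58000 nM in this assay, and the only single change measured, a 3.2-fold lower number from compound 1 to compound 2 (0.51 log units; beyond the scatter), came from putting trifluoromethyl in place of chloro. Compound 4 `COc1cc(NC(C)CCCNC(=O)NNC(=O)Nc2ccc(O)cc2)c2ncccc2c1` differs from compound 2 by hydroxy in place of trifluoromethyl on an aromatic carbon. Going by the values given here, no measured step covers hydroxy; the one step available shows that trifluoromethyl gave a lower number than chloro, so taking it away is expected to raise the number, roughly back toward compound 1. Compound 4 is therefore expected to give 60000 nM, within 20000 nM to 180000 nM, a step of a 3.3-fold higher number from compound 2 to compound 4 (0.52 log units; beyond the scatter).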

Compound 4, half-maximal inhibitory concentration: 95000 nM
Beside the measured number, compound 4's estimate is 1.6-fold (0.20 log units) below it; the range from low to high includes it.
By their numbers in this assay, from the lowest: compounds 2 and 3 (each within the scatter of the next); then compounds 1 and 4 (each within the scatter of the next).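

Putting hydroxy in place of trifluoromethyl in this assay gives a 5.3-fold higher number from compound 2 to compound 4 (0.72 log units; beyond the scatter) and so takes away the lower number that trifluoromethyl had shown against chloro. Hydroxy and chloro cannot be told apart at this position, with a 1.6-fold higher number from compound 1 to compound 4 (0.21 log units; within the scatter), so among these three single groups only trifluoromethyl separates from the others. Nothing given here explains this difference. From the compounds shown here alone, whether an amine, a carboxylic acid or a methoxy group at this position would match trifluoromethyl or instead sit with chloro and hydroxy remains open.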